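The source may hold more compounds than are shown below. What is called first, only, known or untested is meant among the compounds shown, and "the series" means these compounds.

Compound 1 `CN1Cc2c(N)cccc2C(c2ccc(Cl)cc2)C1` gives 1.1 mg/kg
Compound 2 `CCOC(=O)Nc1cccc2c1CN(C)CC2c1ccccc1` gives about 4 mg/kg

In a functional assay on the whole organism for inhibition, with Mus musculus as the target (on this read-out higher numbers stand for an effect only at larger amounts of compound and lower numbers for an effect already at smaller amounts), compound 2 at about 4 mg/kg holds the higher of the two numbers, and the gap down to compound 1 lies beyond the usual scatter. Compound 3 `CCOC(=O)Nc1cccc2c1CN(C)CC2c1ccc(Cl)cc1` is compound 2 with one change, chloro in place of hydrogen on an aromatic carbon. For the measured compounds named here, no pair of measured compounds shows this change alone. Compound 1 carries the same 4-chlorophenyl at 1.1 mg/kg but differs from compound 3 elsewhere in the structure, so it offers only a loose hint. In this assay a small step toward a lower number is expected, an estimated shift (a 1.6-fold lower number from compound 2 to compound 3 (0.20 log units; within the scatter)) that may stay within the scatter. Compound 3 is expected at 2.5 mg/kg (estimated range 0.8 mg/kg to 8 mg/kg).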

Compound 3, dose for half-maximal effect: 0.6 mg/kg
Estimate against measurement, compound 3: 4.2-fold (0.62 log units) above; measured number below the stated range.
By their numbers in this assay, from the lowest: compounds 3 and 1 (each within the scatter of the next); then compound 2.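

In this assay, the change from phenyl to 4-chlorophenyl, on the aromatic carbon para to a large group, gives a 6.7-fold lower number from compound 2 to compound 3 (0.82 log units; beyond the scatter), so chloro alone, with the ethoxycarbonyl on the nitrogen held constant, moves the number beyond the scatter. With the 4-chlorophenyl held constant, ethoxycarbonyl in place of hydrogen on the nitrogen gives a 1.8-fold lower number from compound 1 to compound 3 (0.26 log units; within the scatter), so these two forms of the nitrogen are not told apart on this read-out. Nothing available explains why chloro has this effect at this position.

As far as these compounds go, whether fluoro, bromo, methyl or methoxy at the same carbon would give a similar step remains open, as does the effect of chloro on the other carbons of that ring. From the compounds shown here alone, it is also open whether an acetyl group or a longer carbamate chain on the nitrogen would keep the number of compound 3.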